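Swapping fluoro for methoxy on the pendant phenyl ring

The source may report more compounds than this note shows. Statements on the series, on what has been measured and on what is new or still open speak of the compounds shown alone.

Compound 1 `C#CCNC1CCc2c(SCCc3ccc(Br)cc3)cccc21` in an ADME assay on isolated protein for inhibition of Amine oxidase [flavin-containing] B (Homo sapiens) (a higher number here means a weaker inhibitor, a lower number a stronger inhibitor), gives 1250 nM
Compound 2 `C#CCNC1CCc2c(SCCc3cccc(C)c3)cccc21` in this assay gives 4960 nM
Compound 3 `C#CCNC1CCc2c(SCCc3cccc(F)c3)cccc21` in this assay gives 7810 nM

Compound 3 carries the highest number of the three, but its gap to compound 2 is within the scatter, as a 1.6-fold higher number from compound 2 to compound 3 (0.20 log units; within the scatter) shows, so the two cannot be ranked. Only the gap to compound 1 is real, a 6.2-fold higher number from compound 1 to compound 3 (0.80 log units; beyond the scatter), a modest step. The larger moves, a 4.0-fold higher number from compound 1 to compound 2 (0.60 log units; beyond the scatter) and a 6.2-fold higher number from compound 1 to compound 3 (0.80 log units; beyond the scatter), both exchange a 4-bromophenyl for a ring substituted at the 3-position, so they tell more about that exchange than about the group itself.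

Compound 4 `C#CCNC1CCc2c(SCCc3cccc(OC)c3)cccc21` takes the step (methoxy in place of fluoro on an aromatic carbon). For the measured compounds named here, the only measured step at that same aromatic carbon, from compound 2 to compound 3, was within the scatter. Going by the values given here, no measured compound carries a methoxy, so nothing shows how an added hydrogen-bond acceptor behaves here. The expectation is therefore a step of about a 1.2-fold lower number from compound 3 to compound 4 (0.08 log units; within the scatter), most likely within the scatter, in no firm direction. Compound 4 is estimated at 6500 nM, with a range from 2500 nM to 16000 nM.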

Compound 4, half-maximal inhibitory concentration: 3820 nM
Compound 4: the middle estimate sits 1.7-fold (0.23 log units) above what was measured; low and high end bracket the measured number.
By their numbers in this assay, from the lowest: compound 1; then compounds 4, 2 and 3 (each within the scatter of the next, the first and the last beyond it).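

In this assay, the exchange at this aromatic carbon now gives a readable step: a 2.0-fold lower number from compound 3 to compound 4 (0.31 log units; beyond the scatter) is a modest change and the first at this carbon to lie beyond the scatter. Methoxy cannot be ranked against methyl, however, as a 1.3-fold lower number from compound 2 to compound 4 (0.11 log units; within the scatter) remains within the scatter, so the only separation among the three groups at this carbon is the narrow one between fluoro and methoxy. Replacing the 4-bromophenyl with 3-methoxyphenyl still matters more, with a 3.1-fold higher number from compound 1 to compound 4 (0.49 log units; beyond the scatter) showing that methoxy does not close the gap to compound 1, and no supporting data are available to explain any of these steps.

It remains open whether the advantage of compound 1 belongs to the bromine itself or to its place on the ring, since a 3-bromophenyl compound is not among those shown. Also open, from the compounds shown here alone, is how this same aromatic carbon would respond to an amine, a carboxylic acid or a longer ether such as ethoxy, any of which would test whether the small step seen with methoxy extends further.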